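The compounds below may be only part of what the source reports. "The series", "measured", "known", "first", "only" and "open" are said of these compounds alone.

Among the compounds with values here, compound 3, `COc1ccc(C(=O)/C=C/c2ccc(O)c(O)c2)cc1OC`, gives 18 nM in an assay on RBL-1 cells for inhibition of Polyunsaturated fatty acid 5-lipoxygenase (Rattus norvegicus) (on this read-out higher numbers stand for weaker inhibition and lower numbers for stronger inhibition), which puts it second highest of the three numbers so far: nearest stands compound 1, `COc1ccc(C(=O)/C=C/c2ccc(O)c(O)c2)cc1`, with 20 nM, and furthest compound 2, `COc1cc(C(=O)/C=C/c2ccc(O)c(O)c2)ccc1O`, with 9 nM. Compound 4, `COc1cc(C(=O)/C=C/c2ccc(O)c(O)c2)cc(OC)c1OC`, differs from compound 3 by methoxy in place of hydrogen on an aromatic carbon. The step that bears on this change is a 1.1-fold lower number from compound 1 to compound 3 (0.05 log units; within the scatter), the same kind of addition of a methoxy group on an aromatic carbon; the other step, a 2.0-fold higher number from compound 2 to compound 3 (0.30 log units; within the scatter), concerns a methyl on an oxygen and is only a loose guide. On that basis no step beyond the scatter is expected in this assay, and the estimate for compound 4 is 18 nM, within 8 nM to 40 nM, meaning an expected step of no change at the digits printed from compound 3 to compound 4 (within the scatter).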

Compound 4, half-maximal inhibitory concentration: 16 nM
Compound 4: the middle estimate sits 1.1-fold (0.05 log units) above what was measured, within the range that was stated.
By their numbers in this assay, from the lowest: compounds 2, 4, 3 and 1 (each within the scatter of the next, the first and the last beyond it).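

In this assay, methoxy in place of hydrogen on this aromatic carbon, ortho to a methoxy group, gives a 1.1-fold lower number from compound 3 to compound 4 (0.05 log units; within the scatter). The earlier step of the same kind, a 1.1-fold lower number from compound 1 to compound 3 (0.05 log units; within the scatter), involved a different place on the ring, so this result adds a second methoxy addition that stays within the scatter. No measurement shown accounts for this absence of a clear change. The compounds shown leave open whether an amine, a carboxylic acid or a longer chain at this place would also stay within the scatter.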